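Swapping Fluoro for Bromo on the Shared Core

The compounds below may be only part of what the source reports. "The series", "measured", "known", "first", "only" and "open" are said of these compounds alone.

Of the compounds shown here, three sharing one core have been measured in an assay on C6 glioma cells for displacement of a labelled ligand from sodium- and chloride-dependent glycine transporter 1 (Rattus norvegicus), read by scintillation counting, with stated times of 30 min and 10 min; on this read-out lower numbers stand for stronger inhibition and higher numbers for weaker inhibition. Compound 1 `CCc1nnc(-c2ccc(-c3ccccc3)cc2)n1-c1cccc(C)c1C` gives 940 nM. Compound 2 `CCc1nnc(-c2ccc(-c3ccccc3)cc2)n1-c1cccc(N)c1C` gives 320 nM, and the change from compound 1, amino in place of methyl on an aromatic carbon, reads a 2.9-fold lower number from compound 1 to compound 2 (0.47 log units; beyond the scatter). Compound 3 `CCc1nnc(-c2ccc(-c3ccccc3)cc2)n1-c1cccc(F)c1C` gives 630 nM; the steps leading to it read a 1.5-fold lower number from compound 1 to compound 3 (0.17 log units; within the scatter) and a 2.0-fold higher number from compound 2 to compound 3 (0.29 log units; within the scatter), both inside the usual scatter.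

Compound 4 `CCc1nnc(-c2ccc(-c3ccccc3)cc2)n1-c1cccc(Br)c1C` differs from compound 3 in one place: bromo in place of fluoro on an aromatic carbon. The step that bears most closely on it is the earlier exchange at the same position, fluoro for methyl, which gave a 1.5-fold lower number from compound 1 to compound 3 (0.17 log units; within the scatter), a change that did not clear the scatter. Among the measured compounds shown here, the only exchange that did was the amino step, and nothing in the new change resembles it. Compound 4 is therefore expected to give about 700 nM, within a range from 300 nM to 1600 nM. The estimated step is a 1.1-fold higher number from compound 3 to compound 4 (0.05 log units; within the scatter), expected to stay within the scatter.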

Compound 4, half-maximal inhibitory concentration: 2200 nM
Compound 4: the middle estimate sits 3.1-fold (0.50 log units) below what was measured; the measured number lies above the stated range.
By their numbers in this assay, from the lowest: compounds 2, 3 and 1 (each within the scatter of the next, the first and the last beyond it); then compound 4.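

Among the compounds shown here, the position does not treat all halogens alike: bromo in place of fluoro gives a 3.5-fold higher number from compound 3 to compound 4 (0.54 log units; beyond the scatter) and is the first exchange here to raise the number beyond the scatter. Bromo also separates from the other two groups, with a 2.3-fold higher number from compound 1 to compound 4 (0.37 log units; beyond the scatter) and a 6.9-fold higher number from compound 2 to compound 4 (0.84 log units; beyond the scatter), which makes compound 4 the weakest of the four in this assay even though methyl and fluoro could not be told apart. No supporting measurement accounts for this rise.

On these data alone, whether chloro would fall closer to fluoro or to bromo remains open, as does whether iodo would raise the number further. It is also unknown whether a hydroxyl or methoxy group at this position would repeat the drop seen with amino in place of methyl.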